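Alkyne substituent swap on the shared core

This account rests on a few compounds, and the source may have more. Where it says the series, first, only, none or still open, it means among the compounds named here.

Measured compounds:
compound 1 `CC(O)C#Cc1c(Cl)c2c(Cl)cc(C(N)=O)nc2n1[C@H]1CCCNC1` — 147 nM
compound 2 `CN1CC(C#Cc2c(Cl)c3c(Cl)cc(C(N)=O)nc3n2[C@H]2CCCNC2)CC1=O` — 155 nM

In a functional assay on KG-1 cells (Homo sapiens) for antiproliferative activity (a lower number here means that less compound is needed, a higher number that more compound is needed for the effect), compound 1 gives 147 nM and compound 2 gives 155 nM; the two numbers lie within the scatter of each other, so compound 2 stands level with compound 1 in this assay. The step of a 1.1-fold higher number from compound 1 to compound 2 (0.02 log units; within the scatter) is the only one recorded, and it already exchanges the group on the triple-bonded carbon.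

Compound 3 `NC(=O)c1cc(Cl)c2c(Cl)c(C#CCN3CCCC3=O)n([C@H]3CCCNC3)c2n1` is the next member. It differs from compound 2 by (2-oxopyrrolidin-1-yl)methyl in place of 1-methyl-5-oxopyrrolidin-3-yl on a triple-bonded carbon, again a change of the group on the triple-bonded carbon, here with the same atoms joined differently. Within the data shown here, the only comparable step, a 1.1-fold higher number from compound 1 to compound 2 (0.02 log units; within the scatter), stayed within the scatter, so for compound 3 no step beyond the scatter is expected in this assay, a 1.0-fold lower number from compound 2 to compound 3 (0.01 log units; within the scatter). Compound 3 is therefore estimated at 150 nM, with a range from 60 nM to 400 nM.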

Compound 3, half-maximal effective concentration: 178 nM
For compound 3 the middle estimate is 1.2-fold (0.07 log units) below the measured one; low and high end bracket the measured number.
By their numbers in this assay, from the lowest: compounds 1, 2 and 3 (each within the scatter of the next).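

With the same atoms joined differently, (2-oxopyrrolidin-1-yl)methyl in place of 1-methyl-5-oxopyrrolidin-3-yl on the triple-bonded carbon gives a 1.1-fold higher number from compound 2 to compound 3 (0.06 log units; within the scatter) in this assay, so for this pair the way the five-membered ring is joined leaves no readable mark. Against 1-hydroxyethyl, the same group gives a 1.2-fold higher number from compound 1 to compound 3 (0.08 log units; within the scatter), which places three groups at this position, one without a ring and two with one, within the scatter of each other. Nothing available bears on why these numbers stay level.

As far as these compounds go, whether this flat picture extends to a dimethylaminomethyl group, a carboxylic acid or a longer chain on the triple-bonded carbon remains open. From the compounds shown here alone, with a single read-out, it is also open whether these three groups would stay level in any other assay.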